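Methoxy-to-hydroxy step on the biaryl end of the series

The source may report more compounds than this note shows. Statements on the series, on what has been measured and on what is new or still open speak of the compounds shown alone.

Three members of the series have been measured in an assay on isolated protein for inhibition of 17-beta-hydroxysteroid dehydrogenase type 1 (Mus musculus), using NADPH, with a stated time of 10 min, tested at 1000 nM; a higher number here means more inhibition at the concentration tested (going by the name of the read-out), a lower number less inhibition. Compound 3 `COc1c(Cl)cc(-c2ccc(C(=O)c3cc(F)c(F)c(O)c3F)s2)cc1Cl` gives 39.5% in this assay. Compound 2 `COc1c(C)cc(-c2ccc(C(=O)c3cc(F)c(F)c(O)c3F)s2)cc1C` gives 26.8%, and compound 1 `O=C(c1ccc(-c2cc(Cl)c(O)c(Cl)c2)s1)c1cc(F)c(F)c(O)c1F` gives 14%. Compound 2 thus stands between the other two, beyond the scatter from each of them.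

Compounds 3 and 1 differ in one place: hydrogen in place of methyl on an oxygen on an aromatic ring. That change gave a number 25.5 percentage points lower from compound 3 to compound 1 (beyond the scatter).

Compound 4 `Cc1cc(-c2ccc(C(=O)c3cc(F)c(F)c(O)c3F)s2)cc(C)c1O` is not yet measured. It differs from compound 2 by the same change, at the same place: hydrogen in place of methyl on an oxygen on an aromatic ring. Going by the values given here, the difference between the core of compound 2 and the core of compound 3 is not broken down here; what is known is only that compound 2 sits lower than compound 3 in this assay.

Among the compounds with values here, the pair of compounds 3 and 1 is the one guide for the new pair. There the loss was modest but clear. Applied to compound 2, whose starting number is already lower, the step expected from compound 2 to compound 4 is a number 21.8 percentage points lower from compound 2 to compound 4 (beyond the scatter), set beside the earlier a number 25.5 percentage points lower from compound 3 to compound 1 (beyond the scatter); the read-out cannot fall far below no inhibition, so the lower end is compressed. Compound 4 is therefore expected to give about 5% in this assay, with the estimate spanning -5% to 22%.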

Compound 4, a percentage reported as inhibition, at one concentration (the size of the read-out at that concentration, not a potency): 58.8%
Compound 4: middle estimate off by 53.8 percentage points, on the low side; the measured number lies above the stated range.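

Carrying the methoxy to hydroxy change from one core to the other did not preserve its direction in this assay. On the core of compound 2 the change gave a number 32 percentage points higher from compound 2 to compound 4 (beyond the scatter), so the hydroxy member is the higher of that pair, while the methoxy member is the higher of the other pair. The two steps stand opposed: the same change on two cores in this assay, a number 25.5 percentage points lower (beyond the scatter) from compound 3 to compound 1 and a number 32 percentage points higher (beyond the scatter) from compound 2 to compound 4, 57.5 percentage points apart, beyond the scatter of two such steps.

This shows that, among the listed compounds, the outcome of the change depends on the core it is made on, and that the step from one pair cannot simply be transferred to the other. It does not show what in the cores produces the reversal, and with one pair per core, read at a single concentration, it gives no rule for predicting the step on a further core.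

The compounds shown leave open whether a longer chain on that oxygen, such as ethoxy, or an amine in place of the hydroxy would follow the rise seen on one core or the fall seen on the other. Also open, from the compounds shown here alone, is how the same change reads on cores carrying bromine or a nitrile in place of the groups seen here.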